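The source may hold more compounds than are shown below. What is called first, only, known or untested is meant among the compounds shown, and "the series" means these compounds.

In a functional assay on MC-38 cells (Mus musculus) for antiproliferative activity (a lower number here means a stronger inhibitor, a higher number a weaker inhibitor), compound 1 (`COc1ccc(S(=O)(=O)Nc2cccc3c(C#N)c[nH]c23)cc1`) gives 0.17 ug/mL and compound 2 (`COc1ccc(S(=O)(=O)Nc2cccc3c(Cl)c[nH]c23)cc1`) gives 0.2 ug/mL. Among the measured compounds shown here, compound 2 therefore stands within the scatter of its only measured neighbour, with a 1.2-fold higher number from compound 1 to compound 2 (0.07 log units; within the scatter). Compound 3 (`NS(=O)(=O)Cc1ccc(S(=O)(=O)Nc2cccc3c(Cl)c[nH]c23)cc1`) carries sulfamoylmethyl in place of methoxy on an aromatic carbon, para to a large group (sulfamoylmethyl in place of methoxy on an aromatic carbon). That single step swaps cyano for chloro, so it gives no size for this different change, and no shift beyond the scatter is expected in this assay, though with wide uncertainty. For compound 3 the estimated value is 0.25 ug/mL, with an expected range of 0.07 ug/mL to 0.9 ug/mL. This estimate means an expected 1.3-fold higher number from compound 2 to compound 3 (0.10 log units; within the scatter).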

Compound 3, half-maximal inhibitory concentration: 0.12 ug/mL
Compound 3: the middle estimate sits 2.1-fold (0.32 log units) above what was measured, within the range that was stated.
By their numbers in this assay, from the lowest: compounds 3, 1 and 2 (each within the scatter of the next).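

Among the compounds shown here, the step of a 1.7-fold lower number from compound 2 to compound 3 (0.22 log units; within the scatter) in this assay is the first reading at this position, on an aromatic carbon para to a large group, where the earlier pair held methoxy fixed. Here methoxy can give way to the larger sulfamoylmethyl, which brings a hydrogen-bond donor, without a shift beyond the scatter. No measurement at hand bears on the reason for this result.

On these data alone, whether an amine, a carboxylic acid or a longer chain here would move the number beyond the scatter stays open. So does the effect of sulfamoylmethyl alongside cyano in place of chloro.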